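The source may hold more compounds than are shown below. What is called first, only, known or untested is meant among the compounds shown, and "the series" means these compounds.

Measured compounds:
Compound 1 `CC1=NN(C(=O)CSc2ccccc2)[C@@H](c2cc(Br)cc(Br)c2O)C1`: 10400 nM
Compound 2 `O=C(CSc1ccc([N+](=O)[O-])cc1)N1N=C(c2cc3ccccc3oc2=O)C[C@@H]1c1ccc(C(F)(F)F)cc1`: 7760 nM

In a functional assay on HepG2 cells (Homo sapiens) for cytotoxicity, read by MTT assay, with a stated time of 48 h (on this read-out lower numbers stand for stronger inhibition and higher numbers for weaker inhibition), compound 1 gives 10400 nM. Compound 2 gives 7760 nM in this assay, a number that sits within the usual scatter of compound 1, so neither of the two can be called stronger or weaker. Compound 3 `CC1=NN(C(=O)CSc2ccccn2)[C@@H](c2cc(Br)cc(Br)c2O)C1` has not yet been measured. It differs from compound 1 in one place: pyridin-2-yl in place of phenyl on a sulfur. For the measured compounds named here, no measured pair shows what such an exchange does here, so in this assay the expected step is a 1.1-fold lower number from compound 1 to compound 3 (0.04 log units; within the scatter), nothing beyond the scatter in either direction. Compound 3 is therefore estimated at 9500 nM, within 3500 nM to 26000 nM.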

Compound 3, half-maximal inhibitory concentration: 24700 nM
For compound 3 the middle estimate is 2.6-fold (0.41 log units) below the measured one; measured number inside the range.
By their numbers in this assay, from the lowest: compounds 2 and 1 (each within the scatter of the next); then compound 3.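

In this assay the exchange of phenyl for pyridin-2-yl on the sulfur gives a 2.4-fold higher number from compound 1 to compound 3 (0.38 log units; beyond the scatter), a modest step but one beyond the scatter. So the group on this sulfur is not a neutral spot: one ring nitrogen in place of a carbon, in a ring of the same size, already weakens the effect on these cells. Nothing at hand explains the step. On these data alone, what pyridin-4-yl, a saturated cyclohexyl ring or an aminophenyl group would give on the same sulfur stays open.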